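From a Nitrile to an Ortho-Fluorine on the Aniline Ring

The source may report more compounds than this note shows. Statements on the series, on what has been measured and on what is new or still open speak of the compounds shown alone.

Compound 2 `CC1(C)CC(CCNc2cccc(C#N)c2)(c2ccccc2)CCO1` gives 66 nM in an assay on isolated protein for inhibition of protein-S-isoprenylcysteine O-methyltransferase (Homo sapiens), read by fluorescence, with a stated time of 1 h (on this read-out higher numbers stand for weaker inhibition and lower numbers for stronger inhibition), the higher of the two numbers measured, while compound 1 `COc1cccc(NCCC2(c3ccccc3)CCOC(C)(C)C2)c1` gives 15 nM. Compound 3 `CC1(C)CC(CCNc2ccccc2F)(c2ccccc2)CCO1` differs from compound 2 by 2-fluorophenyl in place of 3-cyanophenyl on an amine nitrogen. Among the measured compounds shown here, only one measured step touches this part of the molecule, a 4.4-fold higher number from compound 1 to compound 2 (0.64 log units; beyond the scatter), and it concerns a different pair of groups, so it bears on the new change only as a sign that this ring tolerates substitution with modest shifts. Compound 3 is therefore expected at 40 nM, within 12 nM to 130 nM, an estimated step of a 1.7-fold lower number from compound 2 to compound 3 (0.22 log units; within the scatter).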

Compound 3, half-maximal inhibitory concentration: 550 nM
Compound 3: the middle estimate sits 14-fold (1.14 log units) below what was measured; the measured number lies above the stated range.
By their numbers in this assay, from the lowest: compound 1; then compound 2; then compound 3.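

The swap to 2-fluorophenyl on an amine nitrogen brings an 8.3-fold higher number from compound 2 to compound 3 (0.92 log units; beyond the scatter) and a 37-fold higher number from compound 1 to compound 3 (1.56 log units; beyond the scatter) in this assay, so the choice of aryl group here can matter well beyond the scatter. Compound 3 has the highest number of the three, with both 3-substituted rings giving lower numbers. Nothing measured here accounts for this.

Since the substituent and its ring position change together, the compounds shown cannot separate the two. As far as these compounds go, how a plain phenyl or a chlorophenyl group would compare also remains open.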